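Aryl variation on a fused pyrazolopyrimidine core: compound 4

A few compounds are considered here, and "the series" means these few. Any claim that something is new, unique, unknown or untested is made for them only; others in the source may bear on it.

Measured so far in a functional assay on MCF7 cells (Homo sapiens) for inhibition, read by CCK-8 assay, with a stated time of 48 h; a higher number here means a weaker inhibitor, a lower number a stronger inhibitor:
compound 1 `COc1cc(-c2ccnc3cc(-c4ccc(C)cc4)nn23)cc(OC)c1OC` gives 47 nM
compound 2 `COc1cc(-c2ccnc3cc(-c4ccc(Cl)cc4)nn23)cc(OC)c1OC` gives 2320 nM
compound 3 `COc1ccc(-c2cc3nccc(-c4cc(OC)c(OC)c(OC)c4)n3n2)cc1F` gives 183 nM

Compound 3 sits second highest of the three numbers: above compound 1 by a 3.9-fold higher number from compound 1 to compound 3 (0.59 log units; beyond the scatter) and below compound 2 by a 13-fold lower number from compound 2 to compound 3 (1.10 log units; beyond the scatter). The step to compound 4 `COc1cc(-c2ccnc3cc(-c4ccc5c(ccn5C)c4)nn23)cc(OC)c1OC` alters the same aryl group: 1-methyl-1H-indol-5-yl in place of 3-fluoro-4-methoxyphenyl on an aromatic carbon.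

Both measured steps touching this group bear on it. Exchanging 4-methylphenyl for 4-chlorophenyl moved the number by a 49-fold higher number from compound 1 to compound 2 (1.69 log units; beyond the scatter), and exchanging 4-chlorophenyl for 3-fluoro-4-methoxyphenyl by a 13-fold lower number from compound 2 to compound 3 (1.10 log units; beyond the scatter); the position is therefore sensitive, and single-ring variants already span a wide band. No bicyclic variant has been measured, so the direction is uncertain. The 1-methyl-1H-indol-5-yl group is expected to land within the band set by compound 1 and compound 2, most likely near compound 3, giving an expected step of a 1.2-fold lower number from compound 3 to compound 4 (0.09 log units; within the scatter). Compound 4 is thus estimated at 150 nM, within the range 30 nM to 800 nM.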

Compound 4, half-maximal inhibitory concentration: 3 nM
Compound 4: the middle estimate sits 50-fold (1.70 log units) above what was measured; the whole stated range lies above it.
By their numbers in this assay, from the lowest: compound 4; then compound 1; then compound 3; then compound 2.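

In this assay, the 1-methyl-1H-indol-5-yl group gives the strongest inhibitor of the four at this carbon, outdoing each single-ring aryl group: 3-fluoro-4-methoxyphenyl (a 61-fold lower number from compound 3 to compound 4 (1.79 log units; beyond the scatter)), 4-methylphenyl (a 16-fold lower number from compound 1 to compound 4 (1.19 log units; beyond the scatter)) and 4-chlorophenyl (a 770-fold lower number from compound 2 to compound 4 (2.89 log units; beyond the scatter)). The position therefore accepts a fused two-ring aryl group, and the band set by the single-ring variants does not bound what this carbon can give. No measurement shown accounts for this gain.

Still open, going by these compounds, is whether the gain needs the methyl on the indole nitrogen or only the fused ring, a question that 1H-indol-5-yl and naphthyl groups would help separate. Also open, on these data alone, is whether an amine or a carboxylic acid on the fused ring would keep this level of inhibition.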